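Swapping the Allylic Chloride for a Benzoate Ester

The compounds below may be only part of what the source reports. "The series", "measured", "known", "first", "only" and "open" are said of these compounds alone.

Measured compounds:
compound 1, `O=C(/C(=C/c1ccc(Cl)cc1)CCl)c1ccccc1`, 22000 nM
compound 2, `O=C(/C(=C/c1ccc(Cl)cc1Cl)CCl)c1ccccc1`, 15000 nM

In a functional assay on HeLa cells (Homo sapiens) for inhibition, read by sulforhodamine B assay, with a stated time of 48 h (a higher number here means a weaker inhibitor of growth, a lower number a stronger inhibitor of growth), compound 2 gives 15000 nM, the lowest of the two numbers recorded; its nearest neighbour is compound 1, which in this assay gives 22000 nM. Among the compounds with values here, the only step between measured compounds, a 1.5-fold lower number from compound 1 to compound 2 (0.17 log units; within the scatter), lies within the scatter and concerns a chloro on an aromatic carbon.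

Compound 3, `O=C(OC/C(=C\c1ccc(Cl)cc1Cl)C(=O)c1ccccc1)c1ccccc1`, differs from compound 2 in another place: benzoyloxy in place of chloro on a saturated chain carbon bound to a double-bonded chain carbon. Within the data shown here, no measured step touches this part of the shared core, so the one recorded step offers no direct guide. With nothing in the data pointing either way, compound 3 is expected to give a number in this assay close to that of compound 2, the estimated step being no change at the digits printed from compound 2 to compound 3 (within the scatter). Compound 3 is therefore estimated at 15000 nM, with a range from 5000 nM to 45000 nM.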

Compound 3, concentration for 50% growth inhibition: 20000 nM
The estimate for compound 3 lay 1.3-fold (0.12 log units) below the measured number; the range from low to high includes it.
By their numbers in this assay, from the lowest: compounds 2, 3 and 1 (each within the scatter of the next).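

Within the data shown here, the step in this assay is a 1.3-fold higher number from compound 2 to compound 3 (0.12 log units; within the scatter) and is the first to touch the saturated chain carbon bound to a double-bonded chain carbon. Here a single chlorine leaves and a benzoyloxy group of nine heavy atoms enters, bringing a six-membered aromatic ring and two hydrogen-bond acceptors, yet compound 2 and compound 3 stay within the scatter of each other, so this position accepts the far larger group without a readable shift in the number. No evidence here accounts for this result.

Going by these compounds, whether an amine, a carboxylic acid or a simple hydroxyl group at this place would move the number beyond the scatter remains open. On these data alone, it is also open whether a substituted benzoyloxy group or a longer chain ester would do so.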